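Variation of the group on the ring amine nitrogen

The source may hold more compounds than are shown below. What is called first, only, known or untested is meant among the compounds shown, and "the series" means these compounds.

Measured so far in a functional assay on CHO cells with adenosine receptor A1 (Homo sapiens) as the target, read by cAMP accumulation and immunoassay, with a stated time of 6 min, tested at 0.1 uM; a lower number here means a stronger effect, a higher number a weaker effect of the compound at the concentration tested:
- compound 1 `COc1ccc(N2CCN(Cc3csc(N)c3C(=O)c3ccc(Cl)cc3)CC2)cc1`: 0%
- compound 2 `Nc1scc(CN2CCN(c3ccncc3)CC2)c1C(=O)c1ccc(Cl)cc1`: 1.4%
- compound 3 `Nc1scc(CN2CCN(C3CCCCCC3)CC2)c1C(=O)c1ccc(Cl)cc1`: 13%

Compound 3 stands highest of the three numbers in this assay; compound 2 is nearest, compound 1 furthest, and both gaps are beyond the scatter. The two aryl-bearing compounds sit close together: a number 1.4 percentage points higher from compound 1 to compound 2 (within the scatter). Moving from either aryl group to cycloheptyl raised the number by a modest amount: a number 13 percentage points higher from compound 1 to compound 3 (beyond the scatter) and a number 11.6 percentage points higher from compound 2 to compound 3 (beyond the scatter).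

Compound 4 `Nc1scc(CN2CCN(c3cccc4ccccc34)CC2)c1C(=O)c1ccc(Cl)cc1` is not yet measured. Its change from compound 3 is naphthalen-1-yl in place of cycloheptyl on an amine nitrogen in a ring. Among the compounds with values here, this returns the position to an aromatic group, so the steps that bear on it are the two aryl-to-cycloheptyl steps read in reverse, each modest and beyond the scatter. A downward step of about that size is therefore expected, a number 9 percentage points lower from compound 3 to compound 4 (within the scatter), landing near the values of compound 1 and compound 2. Compound 4 is estimated at 4%, expected between 0% and 14%; a new aromatic group of this size carries some uncertainty, so the upper end reaches toward compound 3.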

Compound 4, a percentage reported as activity, at one concentration (the size of the read-out at that concentration, not a potency): 0%
For compound 4 the middle estimate is 4 percentage points above the measured one; the range from low to high includes it.
By their numbers in this assay, from the lowest: compounds 1, 4 and 2 (each within the scatter of the next); then compound 3.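

Naphthalen-1-yl, with 10 heavy atoms against the 7 of cycloheptyl, brings the number back down in this assay: a number 13 percentage points lower from compound 3 to compound 4 (beyond the scatter). Among the aromatic groups, a number 1.4 percentage points lower from compound 2 to compound 4 (within the scatter) and no change at the digits printed from compound 1 to compound 4 (within the scatter), so naphthalen-1-yl, pyridin-4-yl and 4-methoxyphenyl cannot be told apart here, and the larger aromatic group carries no visible penalty at this position, leaving cycloheptyl as the only group that stands apart. No supporting data bear on why cycloheptyl differs from the aromatic groups.

The link between a non-aromatic group and a higher number rests on cycloheptyl alone, so a cyclohexyl ring or an open butyl chain on the same nitrogen would be needed to test it. A read-out at one concentration also leaves any ranking of compound 1, compound 2 and compound 4 open.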